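Swapping a Sulfoximine Arm for a Dimethylsulfamoyl Group

The compounds below may be only part of what the source reports. "The series", "measured", "known", "first", "only" and "open" are said of these compounds alone.

Measured so far in a functional assay on MIA PaCa-2 cells (Homo sapiens) for inhibition, read by MTT assay, with a stated time of 3 days; a lower number here means a stronger inhibitor, a higher number a weaker inhibitor:
compound 1, `CCOC(=O)[C@@H]1CCCN(S(=O)(=O)c2ccc(S(=O)(=O)N3CCOCC3)cc2)C1`, gives 4100 nM
compound 2, `CCOC(=O)[C@@H]1CCCN(S(=O)(=O)c2ccc(S(=N)(=O)N(CC)CC)cc2)C1`, gives 900 nM

Among the compounds with values here, compound 2 holds the lower of the two numbers in this assay; the only neighbour is compound 1, and the step of a 4.6-fold lower number from compound 1 to compound 2 (0.66 log units; beyond the scatter) separates them. Compound 3, `CCOC(=O)[C@@H]1CCCN(S(=O)(=O)c2ccc(S(=O)(=O)N(C)C)cc2)C1`, is built from compound 2 by the change (a group of 6 heavy atoms (2 carbon, 1 nitrogen, 2 oxygen, 1 sulfur; no ring) in place of a group of 8 heavy atoms (4 carbon, 2 nitrogen, 1 oxygen, 1 sulfur; no ring), on an aromatic carbon), the new group sitting para to a large group on the ring.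

Within the data shown here, only one measured step exists, a 4.6-fold lower number from compound 1 to compound 2 (0.66 log units; beyond the scatter), and it does not reproduce this change: it exchanges a ring-bearing sulfonyl group for the open-chain sulfoximine, whereas the move to compound 3 replaces that sulfoximine with a smaller open-chain sulfonyl group. The dimethylsulfamoyl group of compound 3 shares its two oxygens and sulfonyl form with the group in compound 1, so a number nearer that of compound 1 than that of compound 2 is the expectation, with wide uncertainty. For compound 3 the step is therefore expected to be a 2.8-fold higher number from compound 2 to compound 3 (0.44 log units; beyond the scatter) in this assay. Compound 3 is estimated at 2500 nM, within 900 nM to 7000 nM.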

Compound 3, half-maximal inhibitory concentration: 300 nM
Compound 3: the middle estimate sits 8.3-fold (0.92 log units) above what was measured, and the stated range ends above it.
By their numbers in this assay, from the lowest: compound 3; then compound 2; then compound 1.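

In this assay, the step to the dimethylsulfamoyl group, a 3.0-fold lower number from compound 2 to compound 3 (0.48 log units; beyond the scatter), shows that a sulfonyl group at this position, on the aromatic carbon para to a large group, can give a lower number than the sulfoximine arm of compound 2, so the high number of compound 1 cannot be read as a feature of the sulfonyl form alone. The step of a 14-fold lower number from compound 1 to compound 3 (1.14 log units; beyond the scatter), with dimethylamino in place of morpholin-4-yl on a sulfonyl sulfur, is the largest of the steps shown and places much of the variation in what the sulfonyl sulfur carries, with the sulfoximine compound 2 lying between the two sulfonyl compounds. Nothing available explains these differences in the numbers.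

The step from compound 2 to compound 3 alters both the sulfur group and the alkyl groups on its nitrogen, so diethylamino on a sulfonyl sulfur, or dimethylamino on the sulfoximine, would be needed to separate the two changes. On these data alone, it also remains open how pyrrolidin-1-yl or piperidin-1-yl on the sulfonyl sulfur would compare with the morpholin-4-yl of compound 1 and the dimethylamino of compound 3.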